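A few compounds are considered here, and "the series" means these few. Any claim that something is new, unique, unknown or untested is made for them only; others in the source may bear on it.

Measured so far on this series:

compound 1 `CC(Sc1nc2c(cnn2C)c(=O)n1-c1ccccc1)c1ccccn1` gives 1.2 h
compound 2 `CC(Sc1nc2nn(C3(C)COC3)cc2c(=O)n1-c1ccccc1)c1ccccc1` gives 1.6 h

Both numbers come from an ADME assay on the whole organism (Mus musculus, strain CD-1) for metabolic stability, read by LC-MS, with a stated time of 4 h, at a dose of 10 mg/kg by the intraperitoneal route; on this read-out higher numbers stand for a longer-lived compound and lower numbers for a shorter-lived compound. Among the measured compounds shown here, compound 1 has the lower of the two figures, with compound 2 returning a figure only marginally above it; the gap between them sits within the scatter, so the two compounds cannot be told apart on this read-out, and no step between them is recorded.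

The next compound to be measured in this assay is compound 3 `C[C@@H](Sc1nc2c(cnn2C)c(=O)n1-c1ccccc1)c1ccccc1`. It keeps the core of compound 1 and changes only the group carried on the sulfur:

1-phenylethyl in place of 1-(pyridin-2-yl)ethyl on a sulfur

The entering 1-phenylethyl is the same group that compound 2 carries on its sulfur, though compound 2 differs from compound 3 elsewhere on the core, so its value is only a loose guide. For the measured compounds named here, with no recorded step to lean on, no change beyond the scatter is expected from compound 1 to compound 3, and the step of a 1.2-fold higher number from compound 1 to compound 3 (0.07 log units; within the scatter) is the estimated size of the move. Compound 3 is expected to give about 1.4 h in this assay, with a likely range from 0.7 h to 2.8 h.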

Compound 3, half-life: 0.5 h
The estimate for compound 3 lay 2.8-fold (0.45 log units) above the measured number; measured number below the stated range.
By their numbers in this assay, from the lowest: compound 3; then compounds 1 and 2 (each within the scatter of the next).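

Within this assay, 1-phenylethyl in place of 1-(pyridin-2-yl)ethyl on a sulfur gives a 2.4-fold lower number from compound 1 to compound 3 (0.38 log units; beyond the scatter), the first recorded step in the series and one that lies beyond the scatter. The read-out therefore responds to a change at this position, although the size of the step is modest. The change is not a clean single-atom comparison: the leaving group has a six-membered aromatic ring with one hetero atom, the entering group has a ring of carbon only, and the entering group also has a defined stereocentre, so this one pair cannot separate the two differences, and no measured evidence is available to explain the step.

The compounds shown leave open how much of the step belongs to the ring nitrogen and how much to the defined stereocentre, a question that the mirror-image form of compound 3 or a stereodefined form of compound 1 would address. They also leave open how the half-life would respond to a pyrimidine ring or a plain benzyl group on the sulfur.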